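Acetyl in place of fluoro: expectation for compound 4

The source may hold more compounds than are shown below. What is called first, only, known or untested is meant among the compounds shown, and "the series" means these compounds.

Among the measured compounds shown here, compound 3 `N#Cc1cccc(C#Cc2cccc(F)n2)c1` gives 210 nM in an in vitro functional assay on HEK293-A cells for agonist activity at metabotropic glutamate receptor 5 (Rattus norvegicus), read by ELISA (a higher number here means a weaker inhibitor, a lower number a stronger inhibitor), the second highest of the three numbers measured so far. Compound 1 `N#Cc1cccc(C#Cc2cccc(C#N)n2)c1` gives 20 nM, and compound 2 `CCCCc1cccc(C#Cc2cccc(C#N)c2)n1` gives 700 nM. Two steps change the same aromatic carbon that is varied here: an 11-fold higher number from compound 1 to compound 3 (1.02 log units; beyond the scatter) and a 3.3-fold lower number from compound 2 to compound 3 (0.52 log units; beyond the scatter). The third step, a 35-fold higher number from compound 1 to compound 2 (1.54 log units; beyond the scatter), connects the other two and is the largest of the set. Compound 4 `CC(=O)c1cccc(C#Cc2cccc(C#N)c2)n1` differs from compound 3 by acetyl in place of fluoro on an aromatic carbon. Of the measured steps, fluoro in place of cyano was large and fluoro in place of butyl was modest, so the group at this position moves this assay well beyond the scatter in either direction. Acetyl brings one hydrogen-bond acceptor where fluoro brought none, which points toward a lower number rather than a higher one, though not back to the level of compound 1. For compound 4 the expected step is a 1.9-fold lower number from compound 3 to compound 4 (0.28 log units; within the scatter). Compound 4 is estimated at 110 nM, within 25 nM to 500 nM.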

Compound 4, half-maximal inhibitory concentration: 300 nM
Compound 4: the middle estimate sits 2.7-fold (0.44 log units) below what was measured; the measured number falls inside the stated range.
By their numbers in this assay, from the lowest: compound 1; then compounds 3 and 4 (each within the scatter of the next); then compound 2.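

In this assay, acetyl and fluoro at this carbon next to the ring nitrogen cannot be told apart (a 1.4-fold higher number from compound 3 to compound 4 (0.15 log units; within the scatter)), so the hydrogen-bond acceptor that acetyl adds over fluoro brings no separation between these two compounds. Acetyl still stands clearly apart from both butyl (a 2.3-fold lower number from compound 2 to compound 4 (0.37 log units; beyond the scatter)) and cyano (a 15-fold higher number from compound 1 to compound 4 (1.18 log units; beyond the scatter)), which leaves cyano alone at the low end of the four groups and shows that an acceptor-bearing group at this carbon does not by itself match it. No measurement available here explains the gap between cyano and acetyl.

From the compounds shown here alone, whether a carboxylic acid, a primary amide or a methyl ester at this carbon would fall with cyano or with acetyl stays open. So does whether a methyl group or a longer chain would differ from butyl.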